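Methyl on the ring nitrogen: compound 2 to compound 3

The compounds below may be only part of what the source reports. "The series", "measured", "known", "first", "only" and "open" are said of these compounds alone.

Measured compounds:
compound 1 `Nc1n[nH]c2cc(-c3ccccn3)[nH]c(=O)c12` — 35%
compound 2 `Cc1cc2[nH]nc(N)c2c(N2CCCCC2)n1` — 87%

In an assay on isolated protein for inhibition of ribosomal protein S6 kinase alpha-5 (Homo sapiens), read by mobility shift assay, tested at 30 uM (a lower number here means less inhibition, a higher number more inhibition at the concentration tested (going by the name of the read-out)), compound 2 gives 87%, the higher of the two numbers recorded. Compound 1 gives 35% in this assay, a gap to compound 2 that lies beyond the usual scatter. Among the compounds with values here, no step between these two is counted, as they differ in more than one place.

Compound 3 `Cc1cc2c(c(N)nn2C)c(N2CCCCC2)n1` has not yet been measured. It differs from compound 2 by methyl in place of hydrogen on an aromatic nitrogen. Within the data shown here, no measured pair shows this change, so the size of the step is uncertain. The expectation is that the step of a number 42 percentage points lower from compound 2 to compound 3 (beyond the scatter) will be a loss of inhibition beyond the scatter, since compound 2 stands high at 87% and there is more room to fall than to rise. Compound 3 is therefore estimated at 45%, within a range from 10% to 80%.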

Compound 3, a percentage reported as inhibition, at one concentration (the size of the read-out at that concentration, not a potency): 7%
Compound 3: the middle estimate sits 38 percentage points above what was measured; the whole stated range lies above it.
By their numbers in this assay, from the lowest: compound 3; then compound 1; then compound 2.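

Within the data shown here, with a single added carbon, the change from hydrogen to methyl on the aromatic nitrogen gives a number 80 percentage points lower from compound 2 to compound 3 (beyond the scatter) in this assay and provides the first step in this set that can be read at one place. It shows that with methyl at this position on the five-membered aromatic ring the number in this assay is lower, a point that the comparison of compound 1 and compound 2, which differ in more than one place, could not show. The data do not separate the loss of the hydrogen from the arrival of the methyl, and nothing available explains the size of the step.

As far as these compounds go, whether a longer chain such as ethyl, or a chain ending in an amine or a carboxylic acid, would fare the same on this nitrogen remains open. Also open, from the compounds shown here alone, is whether methyl on the other nitrogen of the same ring would bring a comparable step.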